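The source may report more compounds than this note shows. Statements on the series, on what has been measured and on what is new or still open speak of the compounds shown alone.

Measured in an ADME assay on L6 cells (Rattus norvegicus) for cytotoxicity, read by resazurin assay, with a stated time of 72 h (a lower number here means a stronger inhibitor, a higher number a weaker inhibitor), so far:

Compound 1, `COc1ccc(-c2noc(CN3N=N[C@@H]4C(=O)N(c5ccccc5)C(=O)[C@@H]43)n2)cc1`, sits at the assay limit of > 100 ug/mL.
Compound 2, `Cc1ccc(-c2noc(CN3N=N[C@@H]4C(=O)N(c5ccccc5)C(=O)[C@@H]43)n2)cc1`, gives 15.2 ug/mL.
Compound 3, `O=C1[C@H]2N=NN(Cc3nc(-c4ccc([N+](=O)[O-])cc4)no3)[C@H]2C(=O)N1c1ccccc1`, sits at the assay limit of > 100 ug/mL.

Compound 3 is one of the two compounds resting at the limit (the limit of > 100 ug/mL in this assay, at which 2 of the 3 values shown sit); no number is known for it, only that it lies past that boundary. Compound 4, `O=C1[C@H]2N=NN(Cc3nc(-c4ccc(Cl)cc4)no3)[C@H]2C(=O)N1c1ccccc1`, differs from compound 3 by chloro in place of nitro on an aromatic carbon.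

Going by the values given here, no measured step introduces a chloro group, so the bearing of the known steps is indirect. The step of an at least 6.5-fold higher number from compound 2 to compound 3 (0.81 log units; beyond the scatter) shows that replacing methyl with nitro moves the value out to the limit, and an at least 6.5-fold lower number from compound 1 to compound 2 (0.81 log units; beyond the scatter) shows methyl giving a clearly lower number than methoxy. The step that the two limits leave unreadable from compound 1 to compound 3 gives no readable size. Removing the nitro group is therefore expected to bring compound 4 back from the limit toward a readable number, though how far is uncertain. For compound 4 the expected step is an at least 2.5-fold lower number from compound 3 to compound 4 (0.39 log units; beyond the scatter). Compound 4 is estimated at 40 ug/mL, within 12 ug/mL to 110 ug/mL.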

Compound 4, half-maximal inhibitory concentration: 49.5 ug/mL
Beside the measured number, compound 4's estimate is 1.2-fold (0.09 log units) below it; low and high end bracket the measured number.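

In this assay, the aromatic carbon para to a large group now carries two groups with readable numbers, and chloro in place of methyl gives a 3.3-fold higher number from compound 2 to compound 4 (0.51 log units; beyond the scatter). Chloro in place of nitro gives an at least 2.0-fold lower number from compound 3 to compound 4 (0.30 log units; that floor lies within the scatter), and chloro in place of methoxy gives an at least 2.0-fold lower number from compound 1 to compound 4 (0.30 log units; that floor lies within the scatter); compound 4 therefore has a readable number, but both floors lie within the scatter and neither step by itself establishes a large change. Compound 1 and compound 3 remain limits rather than numbers, and the true size of these two steps stays unknown: the limit of > 100 ug/mL in this assay, at which 2 of the 4 values shown sit.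

The compounds shown leave open how an amine, a carboxylic acid or a bromo group at this position would read. They also leave open whether the gap between methyl and chloro holds when the phenyl group on the shared core is changed.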